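A Sulfamoyl Swap in a Level Series

The source may hold more compounds than are shown below. What is called first, only, known or untested is meant among the compounds shown, and "the series" means these compounds.

In a functional assay on RKO cells (Homo sapiens) for cytotoxicity, read by resazurin assay, with a stated time of 72 h (a higher number here means a weaker inhibitor, a lower number a stronger inhibitor), compound 1 (`Cc1nc2ccccc2n1-c1csc(Nc2cccc(Br)c2)n1`) gives 85000 nM, compound 2 (`Cc1nc2ccccc2n1-c1csc(Nc2ccc(Br)cc2)n1`) gives 60000 nM and compound 3 (`COc1ccc(Nc2nc(-n3c(C)nc4ccccc43)cs2)cc1`) gives 52500 nM. Compound 3 therefore stands level with the other two, within the scatter. Compound 4 (`Cc1nc2ccccc2n1-c1csc(Nc2ccc(S(N)(=O)=O)cc2)n1`) has sulfamoyl in place of methoxy on an aromatic carbon, para to a large group: sulfamoyl in place of methoxy on an aromatic carbon. Among the measured compounds shown here, two measured steps bear on this place: a 1.1-fold lower number from compound 2 to compound 3 (0.06 log units; within the scatter), and a 1.6-fold lower number from compound 1 to compound 3 (0.21 log units; within the scatter). The step of a 1.4-fold lower number from compound 1 to compound 2 (0.15 log units; within the scatter) is similarly small. For the measured compounds named here, all lie within the scatter, though no measured compound carries sulfamoyl. For compound 4 the expected step is a 1.1-fold lower number from compound 3 to compound 4 (0.02 log units; within the scatter), none beyond the scatter. Compound 4 is estimated at 50000 nM, with an expected range of 20000 nM to 100000 nM.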

Compound 4, half-maximal inhibitory concentration: 95000 nM
Beside the measured number, compound 4's estimate is 1.9-fold (0.28 log units) below it; low and high end bracket the measured number.
By their numbers in this assay, from the lowest: compounds 3, 2, 1 and 4 (each within the scatter of the next).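

Sulfamoyl, para to a large group, is larger than methoxy and carries a hydrogen-bond donor, yet in this assay the change gives a 1.8-fold higher number from compound 3 to compound 4 (0.26 log units; within the scatter). Set against bromo at the same place, it gives a 1.6-fold higher number from compound 2 to compound 4 (0.20 log units; within the scatter), so even this more substantial replacement leaves the series level. Nothing available accounts for this flatness. From the compounds shown here alone, whether a carboxylic acid or an amine at this place would move the number beyond the scatter remains open. So does whether a change to the shared core would do so.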